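A few compounds are considered here, and "the series" means these few. Any claim that something is new, unique, unknown or untested is made for them only; others in the source may bear on it.

Measured in a functional assay on U-251 cells (Homo sapiens) for inhibition, read by sulforhodamine B assay, with a stated time of 48 h; a lower number here means a stronger inhibitor of growth, a higher number a weaker inhibitor of growth:
Compound 1 `Cc1ccc(-c2c(CNC(C)(C)C)c(C(=O)O)nn2-c2ccccc2)cc1`: > 688000 nM (a limit)
Compound 2 `CC(C)(C)NCc1c(C(=O)O)nn(-c2ccccc2)c1-c1ccc([N+](=O)[O-])cc1`: > 634000 nM (a limit)

Compound 1 has no numerical value in this assay, since its > 688000 nM is a limit. Among the measured compounds shown here, the only other compound measured, compound 2, also gives only a limit, > 634000 nM.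

Compound 3 `Cc1ccc(-c2c(CNC(C)(C)C)c(C(=O)O)nn2-c2ccc(Cl)cc2)cc1` keeps the core of compound 1 and changes one place: chloro in place of hydrogen on an aromatic carbon. In words, chloro replaces hydrogen on an aromatic carbon, taking phenyl to 4-chlorophenyl. For the measured compounds named here, only one measured step is available, a step that the two limits leave unreadable from compound 1 to compound 2. It replaces methyl with nitro, which is a different change at a different place, and it has no readable size. It therefore offers no measured guide to the effect of chloro, and no direction can be drawn from it. The expectation is for no step beyond the scatter in this assay, and another limit is the likeliest report. The expected change is an at least 1.0-fold lower number from compound 1 to compound 3 (0.03 log units; that floor lies within the scatter). For compound 3 the estimated value is 630000 nM, with an expected range from 250000 nM to 800000 nM.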

Compound 3, concentration for 50% growth inhibition: > 629000 nM
Compound 3: no number, only a limit; the forecaster's own chance of this, stated with the estimate: 85%; the middle value does not contradict the limit.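

In this assay compound 3 gives > 629000 nM, which is a limit and not a number. Compound 1 also gives only a limit, > 688000 nM, so no step can be read between compound 1 and compound 3. The compounds shown leave open what effect, if any, chloro in place of hydrogen has on growth inhibition in this assay.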